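A few compounds are considered here, and "the series" means these few. Any claim that something is new, unique, unknown or untested is made for them only; others in the source may bear on it.

Compound 3 `CC(C)(C)c1cc(NC(=O)Nc2ccc(-c3cn4ncccc4n3)cc2)no1` gives 59.1 nM in a functional assay on MV4-11 cells (Homo sapiens) for cytotoxicity, read by MTT assay, with a stated time of 72 h (on this read-out higher numbers stand for weaker inhibition and lower numbers for stronger inhibition), the highest number of the three measured. Compound 2 `CC(C)(C)c1cc(NC(=O)Nc2ccc(-c3cn4ccncc4n3)cc2)no1` gives 44.8 nM, and the step of a 1.3-fold higher number from compound 2 to compound 3 (0.12 log units; within the scatter) is within the scatter. Compound 1 `CC(C)(C)c1cc(NC(=O)Nc2ccc(-c3cn4ccccc4n3)cc2)no1`, whose bicyclic group has a six-membered ring of carbon only, gives 3.09 nM; the steps of a 19-fold higher number from compound 1 to compound 3 (1.28 log units; beyond the scatter) and a 14-fold higher number from compound 1 to compound 2 (1.16 log units; beyond the scatter) are both large. Compound 4 `CC(C)(C)c1cc(NC(=O)Nc2ccc(-c3nc4ccccc4o3)cc2)no1` carries the change (a group of 9 heavy atoms (7 carbon, 1 nitrogen, 1 oxygen; one five-membered aromatic ring with 2 hetero atoms, one six-membered aromatic ring of carbon only) in place of a group of 9 heavy atoms (6 carbon, 3 nitrogen; one five-membered aromatic ring with 2 hetero atoms, one six-membered aromatic ring with 2 hetero atoms), on an aromatic carbon). This restores a six-membered ring of carbon only, the feature that separates compound 1 from compound 3, so the step of a 19-fold higher number from compound 1 to compound 3 (1.28 log units; beyond the scatter) bears most directly here and a clear drop in this assay toward compound 1 is expected, though the five-membered ring of compound 4 holds nitrogen and oxygen rather than two nitrogens, so a full reversal is not assumed. The expected step is a 5.9-fold lower number from compound 3 to compound 4 (0.77 log units; beyond the scatter). For compound 4 the estimate is 10 nM, within 3 nM to 40 nM.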

Compound 4, half-maximal inhibitory concentration: 82.6 nM
The estimate for compound 4 lay 8.3-fold (0.92 log units) below the measured number; the measured number lies above the stated range.
By their numbers in this assay, from the lowest: compound 1; then compounds 2, 3 and 4 (each within the scatter of the next).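

In this assay, a six-membered ring of carbon only does not by itself recover the number of compound 1: a 1.4-fold higher number from compound 3 to compound 4 (0.15 log units; within the scatter) and a 1.8-fold higher number from compound 2 to compound 4 (0.27 log units; within the scatter) both lie within the scatter, while a 27-fold higher number from compound 1 to compound 4 (1.43 log units; beyond the scatter) is large. At this position, 1,3-benzoxazol-2-yl therefore stands with the two groups carrying an extra ring nitrogen, leaving the low number with the group of compound 1 alone. Nothing measured here gives a reason for this. Still open, as far as these compounds go, is whether a 1,3-benzothiazol-2-yl group, or an amine added to the group of compound 1, would keep that low number.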